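A few compounds are considered here, and "the series" means these few. Any claim that something is new, unique, unknown or untested is made for them only; others in the source may bear on it.

Measured in an assay for binding affinity to dual specificity mitogen-activated protein kinase kinase 4 (Homo sapiens), read by KINOMEscan, tested at 100 nM; on this read-out lower numbers stand for a stronger effect and higher numbers for a weaker effect at the one concentration tested:
compound 1, `CCCS(=O)(=O)Nc1ccc(F)c(C(=O)c2n[nH]c3ncc(-c4ccc(N)cc4)cc23)c1F`, gives 0.1%
compound 2, `CCCS(=O)(=O)Nc1ccc(F)c(C(=O)c2n[nH]c3ncc(-c4ccc(C(F)(F)F)cc4)cc23)c1F`, gives 29%
compound 3, `CCCS(=O)(=O)Nc1ccc(F)c(C(=O)c2n[nH]c3ncc(-c4ccc(NS(C)(=O)=O)cc4)cc23)c1F`, gives 0.85%

Compound 3 stands second highest of the three numbers in this assay. Its nearest neighbour is compound 1, and the step of a number 0.8 percentage points higher from compound 1 to compound 3 (within the scatter) is within the scatter, so the two cannot be told apart. Its furthest neighbour is compound 2, and the step of a number 28.2 percentage points lower from compound 2 to compound 3 (beyond the scatter) is beyond the scatter. The third step, a number 28.9 percentage points higher from compound 1 to compound 2 (beyond the scatter), shows the same spread from the other side.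

Compound 4, `CCCS(=O)(=O)Nc1ccc(F)c(C(=O)c2n[nH]c3ncc(-c4ccc(-c5nnn[nH]5)cc4)cc23)c1F`, differs from compound 3 in one place:
1H-tetrazol-5-yl in place of methanesulfonamido on an aromatic carbon

Among the measured compounds shown here, the steps that bear on this change are the two that swap the group at this same position, a number 28.2 percentage points lower from compound 2 to compound 3 (beyond the scatter) and a number 28.9 percentage points higher from compound 1 to compound 2 (beyond the scatter); no measured step puts a 1H-tetrazol-5-yl anywhere. The group that leaves and the group that enters both bring 1 hydrogen-bond donor, and two of the three measured groups at this position gave numbers close together, so the expected step of a number 1.2 percentage points higher from compound 3 to compound 4 (within the scatter) is small, most likely within the scatter, with a wider margin towards higher numbers because of the size of a number 28.2 percentage points lower from compound 2 to compound 3 (beyond the scatter). Compound 4 is therefore estimated at 2%, in the range 0.1% to 25%.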

Compound 4, a percentage reported as activity, at one concentration (the size of the read-out at that concentration, not a potency): 0.15%
Compound 4: the middle estimate sits 1.9 percentage points above what was measured, and the stated range covers the measured number.
By their numbers in this assay, from the lowest: compounds 1, 4 and 3 (each within the scatter of the next); then compound 2.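

In this assay, replacing the open-chain methanesulfonamido with a ring, the 1H-tetrazol-5-yl, makes no measurable difference: a number 0.7 percentage points lower from compound 3 to compound 4 (within the scatter). The comparison with the amino group reads the same, a number 0.1 percentage points higher from compound 1 to compound 4 (within the scatter), while the comparison with trifluoromethyl gives a number 28.9 percentage points lower from compound 2 to compound 4 (beyond the scatter), so three different groups now form one cluster, with compound 2 alone outside it. The two groups exchanged here have the same number of heavy atoms and of hydrogen-bond donors, but no measurement shown here explains why compound 4 matches compound 3 or why compound 2 departs from the cluster.

Going by these compounds, it remains open whether a carboxylic acid or a hydroxyl at this position would join the cluster or fall nearer compound 2, and the same question applies to a methyl or a chlorine. With only one concentration tested, the read-out also cannot show whether compound 1, compound 3 and compound 4 would give a stronger or weaker effect than one another at lower concentrations.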